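Urea to amide on the shared core: an expected step

This account rests on a few compounds, and the source may have more. Where it says the series, first, only, none or still open, it means among the compounds named here.

Of the compounds shown here, three built on one core have been measured in a functional assay on SW-620 cells (Homo sapiens) for inhibition, read by sulforhodamine B assay, with a stated time of 48 h, tested at 1 uM; a higher number here means a weaker effect of the compound at the concentration tested, a lower number a stronger effect. Compound 1 `O=C(Nc1cccc(-n2cc(-c3ccncc3)c(-c3cc(O)cc(Cl)c3)n2)c1)Nc1ccc(Cl)c(C(F)(F)F)c1` gives 101% in this assay. Compound 2 `COc1cc(Cl)cc(-c2nn(-c3cccc(NC(=O)Nc4ccc(Cl)c(C(F)(F)F)c4)c3)cc2-c2ccncc2)c1` gives 63%, and compound 3 `COc1cc(Cl)cc(-c2nn(-c3cccc(NC(=O)Nc4cc(C(F)(F)F)cc(C(F)(F)F)c4)c3)cc2-c2ccncc2)c1` gives 19%. Among these numbers compound 2 stands second highest: compound 1 lies above it, and compound 3 lies below it. Within the data shown here, the one single-point step measured so far is a number 38 percentage points lower from compound 1 to compound 2 (beyond the scatter), a change on an oxygen on an aromatic ring.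

Compound 4 `COc1cc(Cl)cc(-c2nn(-c3cccc(NC(=O)c4cccc(C(F)(F)F)c4)c3)cc2-c2ccncc2)c1` has not yet been measured in this assay. It differs from compound 2 in one place: 3-(trifluoromethyl)phenyl in place of (4-chloro-3-(trifluoromethyl)phenyl)amino on a carbonyl carbon. Among the measured compounds shown here, no measured step touches this part of the molecule; the step from compound 1 to compound 2 concerns a different place and offers no guide for it. The values of compound 2 and compound 3 show that changes on the aryl of the urea can move the number widely, but they do not indicate a direction for compound 4. The expectation for compound 4 is therefore a number 12 percentage points higher from compound 2 to compound 4 (beyond the scatter), with wide uncertainty. Compound 4 is estimated at 75%, between 40% and 105%.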

Compound 4, a percentage reported as activity, at one concentration (the size of the read-out at that concentration, not a potency): 107%
Compound 4: the middle estimate sits 32 percentage points below what was measured; the measured number lies above the stated range.
By their numbers in this assay, from the lowest: compound 3; then compound 2; then compounds 1 and 4 (each within the scatter of the next).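

In this assay, the group on the carbonyl carbon proves decisive for the effect at the concentration tested: the move from urea to amide gives a number 44 percentage points higher from compound 2 to compound 4 (beyond the scatter). This change removes the amino nitrogen, with its hydrogen-bond donor, and the chlorine together, so this one step cannot separate their contributions. Nothing available explains the size of the step.

The compounds shown leave open whether a urea bearing 3-(trifluoromethyl)phenyl would retain the effect of compound 2, and whether an amide bearing 4-chloro-3-(trifluoromethyl)phenyl would match compound 4. As far as these compounds go, it also remains open whether a methylene group or an ether oxygen in place of the amino nitrogen would preserve any of the effect.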